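Removing one methyl from compound 2: working notes

The source may hold more compounds than are shown below. What is called first, only, known or untested is meant among the compounds shown, and "the series" means these compounds.

Among the compounds with values here, in a functional assay on HCT-116 cells (Homo sapiens) for inhibition, read by MTT assay, with a stated time of 72 h (a higher number here means a weaker inhibitor of growth, a lower number a stronger inhibitor of growth), compound 2 (`CNC(=O)/C=C/c1ccncc1-c1ccc2c(ccn2C)c1`) gives 4450 nM as the only number available. Compound 1 (`O=C(/C=C/c1ccncc1-c1ccc2[nH]ccc2c1)N1CCOCC1`) stands at "not determined" (no result reported) in the same read-out and so offers no comparison. The open case is compound 3 (`CNC(=O)/C=C/c1ccncc1-c1ccc2[nH]ccc2c1`), which departs from compound 2 by a single change: hydrogen in place of methyl on an aromatic nitrogen. That nitrogen belongs to a five-membered aromatic ring, part of a fused system of two rings, and the rest of the structure stays the same.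

Within the data shown here, no measured pair shows this change, so the data offer no direct guide to its size in this assay or to its direction. A modest gain in growth inhibition is expected, though a result within the usual scatter would be no surprise. The expected change is a 1.8-fold lower number from compound 2 to compound 3 (0.25 log units; within the scatter) as an estimate, in the direction of a lower number. With compound 2 at 4450 nM as the sole anchor, the range has to stay wide. For compound 3 the estimate is 2500 nM and the expected range runs from 700 nM to 8000 nM on repeated measurement.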

Compound 3, concentration for 50% growth inhibition: > 30000 nM
Compound 3 was reported as a limit; the forecaster's own chance of this, stated with the estimate: 8%; middle value at least 12-fold (1.07 log units) from the limit.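

Within the data shown here, this is the first reading of the aromatic nitrogen of the five-membered ring, and the methyl group there matters in this assay. With hydrogen in place of methyl on that nitrogen, the step is an at least 6.7-fold higher number from compound 2 to compound 3 (0.82 log units; beyond the scatter), so the direction is toward weaker growth inhibition and the size is beyond the scatter. In this assay compound 3 gives > 30000 nM, which is a limit of the assay and not a number, so the step is bounded on one side only, and its true size stays unknown: the limit of > 30000 nM in this assay, at which 1 of the 3 values shown sits.

This single pair does not tell whether the methyl group itself is what counts, or whether an ethyl group, a longer chain or an acetyl group on the same nitrogen would hold growth inhibition at the level of compound 2 or move it further. It also leaves open whether the same change would carry the same weight with another amide on the shared core, such as a primary amide or a dimethyl amide, as one pair gives no pattern beyond these two compounds.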